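The compounds below may be only part of what the source reports. "The series", "measured", "known", "first", "only" and "open" are said of these compounds alone.

Compound 3 `Cc1cc(-c2ccsc2)cn2c(CSCCc3ccccc3)cnc12` sits at a limit: in an ADME assay on HEL cells (Homo sapiens) for cytotoxicity, with a stated time of 3 days (a lower number here means that less compound is tolerated, a higher number that more compound is tolerated), it is recorded as > 50 ug/mL, which is the edge of what the assay measures rather than a number. Compound 1 `Cc1cc(-c2ccc(O)cc2)cn2c(CSCCc3ccccc3)cnc12` likewise reaches a limit, giving > 50 ug/mL in this assay. Compound 2 `COc1cccc(-c2cc(C)c3ncc(CSCCc4ccccc4)n3c2)c1` gives a proper number in this assay, 36 ug/mL. Two of the three values therefore rest at the limit of > 50 ug/mL in this assay, at which 2 of the 3 values shown sit. The measured steps are small: an at least 1.3-fold lower number from compound 1 to compound 2 (0.14 log units; that floor lies within the scatter), and an at least 1.3-fold higher number from compound 2 to compound 3 (0.14 log units; that floor lies within the scatter), while a step that the two limits leave unreadable from compound 1 to compound 3.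

Compound 4 `Cc1cc(-c2cccc([N+](=O)[O-])c2)cn2c(CSCCc3ccccc3)cnc12` differs from compound 3 in one place: 3-nitrophenyl in place of thiophen-3-yl on an aromatic carbon. The step that bears most directly on this change is the one in which a six-membered carbon ring replaced the five-membered sulfur ring, and it stayed within the scatter; the exchange of one substituted phenyl for another between compound 1 and compound 2 was also within the scatter. A step beyond the scatter is thus not expected here. Compound 4 is expected to give about 40 ug/mL, within a range from 20 ug/mL to 80 ug/mL. That estimate corresponds to an expected at least 1.2-fold lower number from compound 3 to compound 4 (0.09 log units; that floor lies within the scatter).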

Compound 4, half-maximal cytotoxic concentration: 43 ug/mL
Beside the measured number, compound 4's estimate is 1.1-fold (0.03 log units) below it; the range from low to high includes it.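

In this assay, the exchange of one substituent for another on the same phenyl ring again leaves the number within the scatter, with nitro in place of methoxy giving a 1.2-fold higher number from compound 2 to compound 4 (0.08 log units; within the scatter). The position also takes 3-nitrophenyl, with 9 heavy atoms against 5 for thiophen-3-yl, and no step beyond the scatter appears: the comparisons give an at least 1.1-fold lower number from compound 3 to compound 4 (0.06 log units; that floor lies within the scatter) and an at least 1.1-fold lower number from compound 1 to compound 4 (0.06 log units; that floor lies within the scatter). Those last two steps are only floors, and their true size stays hidden: the limit of > 50 ug/mL in this assay, at which 2 of the 4 values shown sit.

From the compounds shown here alone, it remains open whether an aromatic amine or a carboxylic acid on this phenyl ring would move the number beyond the scatter. A longer chain in place of the aromatic ring at this position is equally untested by these compounds, so the tolerance seen here covers aromatic groups only.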